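Amino in place of tert-butyl on the amide phenyl

The source may hold more compounds than are shown below. What is called first, only, known or untested is meant among the compounds shown, and "the series" means these compounds.

Compound 1 `CN(C)c1ccc(C(=O)Nc2cccc(NC(=O)COc3ccc4c(c3)OCCC4=O)c2)cc1`: 144 nM
Compound 2 `CC(C)(C)c1ccc(C(=O)Nc2cccc(NC(=O)COc3ccc4c(=O)ccoc4c3)c2)cc1`: 165 nM

In an assay on isolated protein for inhibition of Rho-associated protein kinase 1 (Homo sapiens), read by scintillation counting, radiometric assay and 33P incorporation, with a stated time of 40 min, in the presence of a further agent that is not named here (on this read-out higher numbers stand for weaker inhibition and lower numbers for stronger inhibition), compound 1 gives 144 nM and compound 2 gives 165 nM. Of the two numbers, compound 2 has the higher one, but the gap to compound 1 is within the scatter, so the two compounds cannot be told apart on this read-out. Within the data shown here, no step between measured compounds is available here. The unmeasured compound 3 `Nc1ccc(C(=O)Nc2cccc(NC(=O)COc3ccc4c(=O)ccoc4c3)c2)cc1` differs from compound 2 in one place: amino in place of tert-butyl on an aromatic carbon. Nothing in the measured pair speaks directly to this change, so the expectation for compound 3 rests on the values at hand rather than on a shown step. For compound 3 a step of a 1.0-fold lower number from compound 2 to compound 3 (0.01 log units; within the scatter) is expected, that is, no movement beyond the scatter. Compound 3 is therefore estimated at 160 nM, with a likely range from 50 nM to 500 nM.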

Compound 3, half-maximal inhibitory concentration: 802 nM
Compound 3: the middle estimate sits 5.0-fold (0.70 log units) below what was measured, outside the stated range (above it).
By their numbers in this assay, from the lowest: compounds 1 and 2 (each within the scatter of the next); then compound 3.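

In this assay, this aromatic carbon proves sensitive to what it carries: amino in place of tert-butyl gives a 4.9-fold higher number from compound 2 to compound 3 (0.69 log units; beyond the scatter), a step beyond the scatter towards weaker inhibition. The earlier compounds shown here could not show this, since compound 1 and compound 2 differ in more than one place and their numbers lie within the scatter of each other. The step shows that, on this core, the carbon-only tert-butyl cannot be replaced by the smaller amino group, which brings a hydrogen-bond donor and acceptor, without a loss of inhibition, and nothing measured here accounts for that loss.

The compounds shown leave open whether the loss follows from losing tert-butyl or from gaining amino. An isopropyl or a methoxy group at this place could help to separate the two.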